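The compounds below may be only part of what the source reports. "The series", "measured", "known", "first", "only" and "open" are said of these compounds alone.

Measured so far in an assay on cells for inhibition of cytochrome P450 11B2, mitochondrial (Homo sapiens), read by HTRF; on this read-out lower numbers stand for stronger inhibition and higher numbers for weaker inhibition:
compound 1 `CCS(=O)(=O)N1CC(Oc2cncc(N3C(=O)c4ccc(Cl)cc4C3(C)C)c2)C1`: 4 nM
compound 2 `CC(=O)N1CC[C@H](Oc2cncc(N3C(=O)c4ccc(Cl)cc4C3(C)C)c2)C1`: 7 nM

Compound 1 holds the lowest of the two numbers; its nearest neighbour is compound 2, and the step of a 1.8-fold higher number from compound 1 to compound 2 (0.24 log units; within the scatter) lies within the scatter. Compound 3 `Cn1cc(C(=O)N2CC(Oc3cncc(N4C(=O)c5ccc(Cl)cc5C4(C)C)c3)C2)cn1` carries (1-methyl-1H-pyrazol-4-yl)carbonyl in place of ethylsulfonyl on an amine nitrogen in a ring. For the measured compounds named here, the only measured step swaps the whole group on the ring oxygen, sulfonyl included, and moved nothing beyond the scatter; it bears on the new change only loosely. For compound 3 the expected step is a 1.5-fold higher number from compound 1 to compound 3 (0.18 log units; within the scatter), none beyond the scatter. Compound 3 is estimated at 6 nM, between 2 nM and 20 nM.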

Compound 3, half-maximal inhibitory concentration in the cytochrome P450 11B2, mitochondrial assay: 0.5 nM
The estimate for compound 3 lay 12-fold (1.08 log units) above the measured number; measured number below the stated range.
By their numbers in the cytochrome P450 11B2, mitochondrial assay, from the lowest: compound 3; then compounds 1 and 2 (each within the scatter of the next).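

In the cytochrome P450 11B2, mitochondrial assay, (1-methyl-1H-pyrazol-4-yl)carbonyl in place of ethylsulfonyl on this amine nitrogen gives an 8.0-fold lower number from compound 1 to compound 3 (0.90 log units; beyond the scatter), so the group on this nitrogen alone can move the number beyond the scatter, which the earlier step, with its swap of the whole group on the ring oxygen, did not show. In a physicochemical assay for solubility, in phosphate buffer, with a stated time of 2 h, at pH 6.5 (on this read-out higher numbers stand for higher solubility and lower numbers for lower solubility), compound 1 gives 78 ug/mL and compound 3 gives 310 ug/mL. The same change therefore also goes with higher solubility: the measured solubility of compound 1, 78 ug/mL, and of compound 3, 310 ug/mL, a 4.0-fold higher number (0.60 log units; beyond the scatter)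

Going by these compounds, the carbonyl and the pyrazole ring entered together, so which of them carries either step stays open. A benzoyl group on this nitrogen would help to separate them.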